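This account rests on a few compounds, and the source may have more. Where it says the series, first, only, none or still open, it means among the compounds named here.

Measured so far in an assay on cells for inhibition of Protein-serine O-palmitoleoyltransferase porcupine (Homo sapiens), read by reporter gene assay; on this read-out higher numbers stand for weaker inhibition and lower numbers for stronger inhibition:

compound 1 `CN1C(=O)C2=C(C1=O)N(CC(=O)Nc1ccc(-c3ccccc3)cc1)CCC2` — 12 nM
compound 2 `CN1C(=O)C2=C(C1=O)N(CC(=O)Nc1ccc(-c3ccccc3)nn1)CCC2` — 1 nM
compound 3 `Cc1ccc(-c2ccc(NC(=O)CN3CCCC4=C3C(=O)N(C3CC3)C4=O)nn2)cn1` — 12 nM

Compound 1 and compound 3 are level at the digits shown, and together they stand at the high end of the three numbers; compound 2 sits clearly lower, beyond the scatter, so of the three it is the strongest inhibitor on this read-out. Compound 2 differs from compound 1 in the central ring of the anilide portion, and compound 3 differs from compound 1 in several places at once, so neither pair isolates a single change.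

Compound 4 `CN1C(=O)C2=C(C1=O)N(CC(=O)Nc1ccc(-c3cccnc3)cc1)CCC2` carries one change against compound 1: pyridin-3-yl in place of phenyl on an aromatic carbon. For the measured compounds named here, no measured pair shows this change on its own. Compound 3 also carries a pyridyl at the outer end, but with further changes at the core and the central ring, and its value beside that of compound 1 shows only that the two are level. On that basis the step from compound 1 to compound 4 is expected to be small, estimated as a 1.5-fold lower number from compound 1 to compound 4 (0.18 log units; within the scatter), most likely within the scatter. Compound 4 is therefore expected to give about 8 nM in this assay, with a likely range from 2 nM to 30 nM.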

Compound 4, half-maximal inhibitory concentration: 8 nM
The estimate for compound 4 equals the measured number at the digits printed; measured number inside the range.
By their numbers in this assay, from the lowest: compound 2; then compounds 4, 1 and 3 (each within the scatter of the next).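

In this assay, pyridin-3-yl in place of phenyl on an aromatic carbon, para to a large group, gives a 1.5-fold lower number from compound 1 to compound 4 (0.18 log units; within the scatter). For the compounds shown here, this is the first reading of a single change at this position, and on this read-out compound 1 and compound 4 cannot be told apart, so the outer ring accepts one ring nitrogen and one hydrogen-bond acceptor without a step beyond the scatter. Nothing at hand bears on the reason for this result.

The compounds shown leave open whether this holds for the other attachments of the same ring, such as pyridin-2-yl or pyridin-4-yl, or for groups of another kind at this position, such as a primary amine, a carboxylic acid or a morpholine ring. They also leave open whether pyridin-3-yl in place of phenyl gives a similar step on compound 2, whose number is the lowest so far and where a step of the same kind could read differently.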